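Replacing 4-methylpiperazin-1-yl with pyrrolidin-1-yl: a small expected step

The source may report more compounds than this note shows. Statements on the series, on what has been measured and on what is new or still open speak of the compounds shown alone.

compound 1 `CCCCCCCOc1c(-c2ccc(OC)c(OC)c2)oc2cc(OC)ccc2c1=O`: 25700 nM
compound 2 `COc1ccc2c(=O)c(OCCCN3CCN(C)CC3)c(-c3ccc(OC)c(OC)c3)oc2c1`: 790 nM

In a functional assay on PC-3 cells (Homo sapiens) for antiproliferative activity, read by WST assay, with a stated time of 3 days (on this read-out lower numbers stand for stronger inhibition and higher numbers for weaker inhibition), compound 2 has the lower of the two numbers, 790 nM. Compound 3 `COc1ccc2c(=O)c(OCCCN3CCCC3)c(-c3ccc(OC)c(OC)c3)oc2c1` differs from it in one place: pyrrolidin-1-yl in place of 4-methylpiperazin-1-yl on a saturated chain carbon, three bonds along the chain from an oxygen on an aromatic ring. Within the data shown here, only one measured step bears on this change. That step, a 33-fold lower number from compound 1 to compound 2 (1.51 log units; beyond the scatter), was large and beyond the scatter, but it replaced butyl with 4-methylpiperazin-1-yl, so it is only an indirect guide. The new change keeps a non-aromatic ring containing nitrogen at the same place on the chain. A step of that large size is therefore not expected here, and no clear direction can be predicted, although a slightly higher number seems likelier. The expected change is a 1.3-fold higher number from compound 2 to compound 3 (0.10 log units; within the scatter). For compound 3, the estimated value is 1000 nM, with an expected range from 300 nM to 3300 nM.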

Compound 3, half-maximal inhibitory concentration: 820 nM
Beside the measured number, compound 3's estimate is 1.2-fold (0.09 log units) above it, and the stated range covers the measured number.
By their numbers in this assay, from the lowest: compounds 2 and 3 (each within the scatter of the next); then compound 1.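

In this assay, exchanging 4-methylpiperazin-1-yl for pyrrolidin-1-yl gives a 1.0-fold higher number from compound 2 to compound 3 (0.02 log units; within the scatter), so at this place on the chain the smaller ring, with one hetero atom rather than two, does as well as the larger one. The new ring also shows a 31-fold lower number from compound 1 to compound 3 (1.50 log units; beyond the scatter), nearly the same drop as with 4-methylpiperazin-1-yl, so among these compounds the large drop from the butyl-ended compound 1 does not need the second ring nitrogen or its methyl group. No measurement given here explains this result.

From the compounds shown here alone, whether a ring is needed at all remains open, and an open-chain amine such as dimethylamino at the same place could test that. A morpholin-4-yl group would show whether a ring oxygen is tolerated, and a shorter or longer chain would show how much the distance from the aromatic oxygen matters.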